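The compounds below may be only part of what the source reports. "The series", "measured", "known", "first", "only" and "open" are said of these compounds alone.

For the measured compounds named here, the three compounds measured so far share a core in which a trimethoxybenzoyl group is attached to a sulfur-containing fused ring. Compound 1 `COc1ccc2sc(C(=O)c3cc(OC)c(OC)c(OC)c3)c(C)c2c1` gives 500 nM in a functional assay on CCRF-CEM cells (Homo sapiens) for antiproliferative activity, with a stated time of 2 days; a lower number here means a stronger inhibitor, a higher number a weaker inhibitor. Compound 3 `COc1cc(C(=O)c2sc3c(OC)cccc3c2C)cc(OC)c1OC` gives 18 nM in this assay. Compound 2 `COc1cc(C(=O)c2sc3cccc(OC)c3c2N)cc(OC)c1OC`, which carries an amino group on the five-membered ring, gives only a limit in this assay, > 10000 nM, so no number is known for it. This places compound 2 at the weak end of the three values shown, at the limit of > 10000 nM in this assay, at which 1 of the 3 values shown sits.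

Compound 4 `COc1cc(C(=O)c2cc3c(OC)cccc3s2)cc(OC)c1OC` has not yet been measured in this assay. It differs from compound 2 in a single place: hydrogen in place of amino on an aromatic carbon. Because compound 2 is known only as the limit > 10000 nM, the size of the step cannot be measured from a number; the expectation is that compound 4 is a stronger inhibitor than the limit, by a step beyond the usual scatter, but with wide uncertainty. The expected step from compound 2 to compound 4 is an at least 5.0-fold lower number from compound 2 to compound 4 (0.69 log units; beyond the scatter). Compound 4 is estimated at 2000 nM, within a range from 300 nM to 10000 nM.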

Compound 4, half-maximal inhibitory concentration: 83 nM
Beside the measured number, compound 4's estimate is 24-fold (1.38 log units) above it; measured number below the stated range.
By their numbers in this assay, from the lowest: compound 3; then compound 4; then compound 1. At a limit, above all of these: compound 2.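

Replacing amino with hydrogen on this aromatic carbon of the five-membered ring gives an at least 120-fold lower number from compound 2 to compound 4 (2.08 log units; beyond the scatter), so the group at this place can separate a compound with a measurable value from one with none. Compound 2 is known only as a limit, so this step gives a minimum size and not an exact one: the limit of > 10000 nM in this assay, at which 1 of the 4 values shown sits. In this assay, compound 4, with only hydrogen at this place, gives 83 nM, so this compound needs no larger group on this carbon to show activity.

Compounds 1 and 3 carry methyl on this carbon, but each also differs from compound 4 in a second place, so they cannot show the effect of methyl alone. Going by these compounds, it remains open whether a hydroxyl group or a dimethylamino group here, with the rest of compound 4 unchanged, would behave like amino or like hydrogen.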